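Swapping the thiophene for chlorophenyl on an inactive aniline

The source may hold more compounds than are shown below. What is called first, only, known or untested is meant among the compounds shown, and "the series" means these compounds.

Measured so far:
compound 1 `Nc1cccc(-c2cn3nc(-c4cccs4)sc3n2)c1` gives > 250000 nM in a functional assay on CCRF-CEM cells (Homo sapiens) for inhibition, read by cell counting, with a stated time of 3 days; a higher number here means a weaker inhibitor, a lower number a stronger inhibitor;
compound 2 `C=C(Br)C(=O)Nc1cccc(-c2cn3nc(-c4cccc(OC)c4)sc3n2)c1` gives 1200 nM in this assay;
compound 3 `C=C(Br)C(=O)Nc1cccc(-c2cn3nc(-c4cccs4)sc3n2)c1` gives 410 nM in this assay.

Compound 1 sits at the limit of this assay, so only a bound is known for it (the limit of > 250000 nM in this assay, at which 1 of the 3 values shown sits). Compound 4 `Nc1cccc(-c2cn3nc(-c4ccc(Cl)cc4)sc3n2)c1` differs from it by 4-chlorophenyl in place of thiophen-2-yl on an aromatic carbon. Within the data shown here, no measured step covers this swap on the free aniline. Among the measured compounds shown here, the one aryl change measured, a 2.9-fold lower number from compound 2 to compound 3 (0.47 log units; beyond the scatter), is modest, while an at least 600-fold lower number from compound 1 to compound 3 (2.78 log units; beyond the scatter) shows the acyl group carrying the potency. Compound 4 keeps the free aniline, so it is expected to stay at the limit, an expected step of a number no higher from compound 1 to compound 4 (the limit leaves the size open). Compound 4 is therefore estimated at 250000 nM, between 100000 nM and 1000000 nM.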

Compound 4, half-maximal inhibitory concentration: > 250000 nM
Compound 4 gave a limit, no number (the forecaster's own chance of this, stated with the estimate: 85%); the middle value lies on the limit itself.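

Compound 1 and compound 4 both sit at a limit in this assay, so no step can be read between them: the limit of > 250000 nM in this assay, at which 2 of the 4 values shown sit.

The compounds shown leave open whether 4-chlorophenyl in place of thiophen-2-yl changes the free aniline's activity at all.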